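The source may hold more compounds than are shown below. What is called first, only, known or untested is meant among the compounds shown, and "the series" means these compounds.

Measured compounds in a functional assay on ECa-109 cells for antiproliferative activity against ECa-109 cell line (Homo sapiens), read by MTT assay, with a stated time of 72 h; a higher number here means a weaker inhibitor, a lower number a stronger inhibitor:
compound 1 `O=C(N/N=C/c1ccco1)c1cccc(S(=O)(=O)N2CCOCC2)c1`: > 100000 nM, a limit of the assay, the limit of > 100000 nM in this assay, at which 1 of the 3 values shown sits.
compound 2 `O=C(N/N=C/c1ccccn1)c1cccc(S(=O)(=O)N2CCOCC2)c1`: 55700 nM
compound 3 `O=C(N/N=C/c1ccccc1O)c1cccc(S(=O)(=O)N2CCOCC2)c1`: 14400 nM

Compound 3 holds the lowest of the two numbers given; its nearest neighbour is compound 2, the gap being a 3.9-fold lower number from compound 2 to compound 3 (0.59 log units; beyond the scatter). The other ring swaps gave an at least 6.9-fold lower number from compound 1 to compound 3 (0.84 log units; beyond the scatter) and an at least 1.7-fold lower number from compound 1 to compound 2 (0.25 log units; that floor lies within the scatter).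

Compound 4 `CCN(CC)c1ccc(/C=N/NC(=O)c2cccc(S(=O)(=O)N3CCOCC3)c2)c(O)c1` carries diethylamino in place of hydrogen on an aromatic carbon. Going by the values given here, none of the measured steps changes a substituent on the ring kept in compound 3; all three exchange the whole ring, so they bear on this change only loosely. A small to modest step toward a lower number is expected, a 1.8-fold lower number from compound 3 to compound 4 (0.26 log units; within the scatter). Compound 4 is estimated at 8000 nM, within a range from 2000 nM to 30000 nM.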

Compound 4, half-maximal inhibitory concentration: 730 nM
Compound 4: the middle estimate sits 11-fold (1.04 log units) above what was measured; measured number below the stated range.
By their numbers in this assay, from the lowest: compound 4; then compound 3; then compound 2. At a limit, above all of these: compound 1.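

Where the earlier compounds exchanged the whole ring, this change keeps the 2-hydroxyphenyl ring and adds diethylamino on an aromatic carbon, meta to the hydroxy group and para to a large group, giving in this assay a 20-fold lower number from compound 3 to compound 4 (1.30 log units; beyond the scatter). This position on the ring therefore strongly affects the antiproliferative read-out, so the choice of ring is not the only variable that matters. Nothing at hand accounts for the step.

From the compounds shown here alone, whether the effect needs the whole diethylamino group remains open, since a smaller amine such as dimethylamino or a methoxy group at this place would test it. Whether it persists without the hydroxy group is also unresolved.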